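Trading a hydroxy group for a hexyl chain

The source may report more compounds than this note shows. Statements on the series, on what has been measured and on what is new or still open speak of the compounds shown alone.

Compound 2 `[O-][n+]1nc(NCCO)[n+]([O-])c2ccccc21` is one of three analogues of a shared core that have been tested in a functional assay on PC-3 cells (Homo sapiens) for cytotoxicity, read by MTT assay, with a stated time of 48 h; a lower number here means a stronger inhibitor, a higher number a weaker inhibitor. In this assay compound 2 gives 22400 nM, the highest of the three numbers. Compound 1 `[O-][n+]1nc(NCc2ccccc2)[n+]([O-])c2ccccc21` gives 10700 nM, and compound 3 `[O-][n+]1nc(NC2CC2)[n+]([O-])c2ccccc21` gives 15900 nM. The step of a 2.1-fold higher number from compound 1 to compound 2 (0.32 log units; beyond the scatter) lies beyond the scatter, whereas the step of a 1.4-fold lower number from compound 2 to compound 3 (0.15 log units; within the scatter) stays within it.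

Compound 4 `CCCCCCCCNc1n[n+]([O-])c2ccccc2[n+]1[O-]` differs from compound 2 by a single change: hexyl in place of hydroxy on a saturated chain carbon, two bonds along the chain from a nitrogen on an aromatic ring. Both measured steps bear on this change in the same sense. Compound 2, which carries the hydroxy group, stands highest, and replacing its side chain either by a cyclopropyl group, as in compound 3, or by a benzyl-type chain, as in compound 1, leaves the number the same or lowers it by a modest amount. Compound 4 removes the hydroxy and extends the chain, so a modest lowering in this assay is expected, roughly the size of those two steps, and compound 4 is estimated at 11000 nM with a range from 4500 nM to 27000 nM. That estimate means an expected step of a 2.0-fold lower number from compound 2 to compound 4 (0.31 log units; beyond the scatter).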

Compound 4, half-maximal inhibitory concentration: 18200 nM
For compound 4 the middle estimate is 1.7-fold (0.22 log units) below the measured one; measured number inside the range.
By their numbers in this assay, from the lowest: compounds 1, 3, 4 and 2 (each within the scatter of the next, the first and the last beyond it).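

In this assay, the step of a 1.2-fold lower number from compound 2 to compound 4 (0.09 log units; within the scatter) shows that this position accepts hexyl in place of hydroxy without a change beyond the scatter, even though the swap removes the only hydrogen-bond donor and acceptor counted in the leaving group and brings in a purely carbon chain. The earlier compounds shown here had varied the whole side chain but had not tested a long open chain here, and the number of the chain bearing hexyl cannot be told apart from that of compound 2. The step of a 1.7-fold higher number from compound 1 to compound 4 (0.23 log units; within the scatter) also stays within the scatter, so compound 4 cannot be told apart from compound 1 either, although compounds 1 and 2 lie beyond the scatter of each other, and nothing shown here bears on the reason for this result.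

The compounds shown leave open whether an amine or a carboxylic acid at this place on the chain would give a step beyond the scatter. They also leave open whether a chain longer than hexyl, or a phenyl group carried further out along the chain, would do so.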